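The source may hold more compounds than are shown below. What is called first, only, known or untested is meant among the compounds shown, and "the series" means these compounds.

Three related compounds have so far been tested in a functional assay on PC-3 cells (Homo sapiens) for inhibition, read by MTT assay, with a stated time of 48 h; a lower number here means a stronger inhibitor, a higher number a weaker inhibitor. Compound 1 `COc1cc(OC)c(-c2nc3cc(/C=C4\SC(=O)NC4=O)ccc3[nH]2)cc1OC` gives 6320 nM. Within the data shown here, compound 2 `COc1cc(OC)c(-c2nc3cc(/C=C4\SC(=O)N(CC(=O)N5CCOCC5)C4=O)ccc3[nH]2)cc1OC`, which carries a ((morpholin-4-yl)carbonyl)methyl group on the amide-type nitrogen of its five-membered ring, gives 11700 nM; the step of a 1.9-fold higher number from compound 1 to compound 2 (0.27 log units; within the scatter) is the only single-change comparison available. Compound 3 `COc1cc(-c2nc3cc(/C=C4\SC(=O)N(CC(=O)N5CCCCC5)C4=O)ccc3[nH]2)cc(OC)c1OC` gives 14700 nM, the highest of the three numbers, though it sits within the scatter of compound 2 and beyond it only against compound 1. Compound 2 and compound 3 differ in two places at once, so their values alone show no single cause.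

Compound 4 `COc1cc(OC)c(-c2nc3cc(/C=C4\SC(=O)N(CC(=O)N5CCCCC5)C4=O)ccc3[nH]2)cc1OC` is still to be measured. Its difference from compound 3 is 2,4,5-trimethoxyphenyl in place of 3,4,5-trimethoxyphenyl on an aromatic carbon. Among the measured compounds shown here, no measured pair isolates this change of the trimethoxyphenyl pattern; the one measured step concerns a different position and was itself within the scatter. With no evidence that the aryl change matters, compound 4 is expected to land near compound 3, a step of a 1.2-fold lower number from compound 3 to compound 4 (0.09 log units; within the scatter) in this assay. The estimate for compound 4 is therefore 12000 nM, with a range from 5000 nM to 28000 nM.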

Compound 4, half-maximal inhibitory concentration: > 50000 nM
Compound 4 was reported as a limit (the forecaster's own chance of this, stated with the estimate: 5%); middle value at least 4.1-fold (0.61 log units) away from the limit.
By their numbers in this assay, from the lowest: compounds 1, 2 and 3 (each within the scatter of the next, the first and the last beyond it). At a limit, above all of these: compound 4.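

In this assay the reading for compound 4 is a limit and not a number: the limit of > 50000 nM in this assay, at which 1 of the 4 values shown sits. Even so, the aryl group on the aromatic carbon between two ring nitrogen atoms proves sensitive to how its methoxy groups are arranged: 2,4,5-trimethoxyphenyl in place of 3,4,5-trimethoxyphenyl gives an at least 3.4-fold higher number from compound 3 to compound 4 (0.53 log units; beyond the scatter), although the two groups have the same atoms, joined differently. The other two single changes are also beyond the scatter, unlike the earlier 1.9-fold higher number from compound 1 to compound 2 (0.27 log units; within the scatter): piperidin-1-yl in place of morpholin-4-yl on a carbonyl carbon gives an at least 4.2-fold higher number from compound 2 to compound 4 (0.63 log units; beyond the scatter), and ((piperidin-1-yl)carbonyl)methyl in place of hydrogen on the amide-type nitrogen gives an at least 7.9-fold higher number from compound 1 to compound 4 (0.89 log units; beyond the scatter).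

Among these compounds, the only pair isolating the aryl change carries the piperidin-1-yl amide, so it remains open whether the same change would matter as much with the morpholin-4-yl amide or with the hydrogen on that nitrogen. Also open, on these data alone, is how a piperazine amide or a free carboxylic acid on the same methylene would behave alongside the 2,4,5-trimethoxyphenyl group.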